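The compounds below may be only part of what the source reports. "The series", "measured", "known", "first", "only" and "open" are said of these compounds alone.

Measured so far in an assay on CHO-K1 cells for displacement of a labelled ligand from prostaglandin E2 receptor EP1 subtype (Homo sapiens); on this read-out lower numbers stand for stronger inhibition and higher numbers for weaker inhibition:
compound 1 `Cc1cc(C(N)=O)nn1Cc1cc(Cl)ccc1OCc1ccccc1` gives 126 nM;
compound 2 `CNC(=O)c1cc(C)n(Cc2cc(Cl)ccc2OCc2ccccc2)n1` gives 100 nM;
compound 3 `Cc1cc(C(=O)Nc2cccc(F)c2)nn1Cc1cc(Cl)ccc1OCc1ccccc1` gives 200 nM.

Compound 1 sits second highest of these three numbers, with a 1.3-fold lower number from compound 1 to compound 2 (0.10 log units; within the scatter) and a 1.6-fold higher number from compound 1 to compound 3 (0.20 log units; within the scatter), both within the scatter. Compound 4 `Cc1cc(NC(=O)C(C)C)nn1Cc1cc(Cl)ccc1OCc1ccccc1` carries a different change: (isopropylcarbonyl)amino in place of carbamoyl on an aromatic carbon. The measured steps all swap the group on the amide-type nitrogen and leave the carbamoyl attached to the core; none replaces the carbamoyl itself, so they bear on compound 4 only by showing that this part of the molecule has so far tolerated changes with small steps. No step beyond the scatter is therefore expected in this assay, in either direction. Compound 4 is expected to give 160 nM, between 50 nM and 500 nM, an estimated 1.3-fold higher number from compound 1 to compound 4 (0.10 log units; within the scatter).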

Compound 4, half-maximal inhibitory concentration: 25.1 nM
Compound 4: the middle estimate sits 6.4-fold (0.80 log units) above what was measured; the whole stated range lies above it.
By their numbers in this assay, from the lowest: compound 4; then compounds 2, 1 and 3 (each within the scatter of the next).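

In this assay, putting (isopropylcarbonyl)amino in place of carbamoyl on this aromatic carbon gives a 5.0-fold lower number from compound 1 to compound 4 (0.70 log units; beyond the scatter) and is the first change shown to move the number beyond the scatter. Against the two amides with a substituted nitrogen, it gives a 4.0-fold lower number from compound 2 to compound 4 (0.60 log units; beyond the scatter) and an 8.0-fold lower number from compound 3 to compound 4 (0.90 log units; beyond the scatter) as well. Changing the group attached to this ring carbon therefore matters more here than the changes on the amide nitrogen did.

No measurement shown explains this gain. As far as these compounds go, it also remains open how a plain amine, an acetylamino group or a longer acyl chain at this carbon would compare.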